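A few compounds are considered here, and "the series" means these few. Any claim that something is new, unique, unknown or untested is made for them only; others in the source may bear on it.

Compound 1 `O=C(CCc1ccc(C(F)(F)F)cc1)Nc1ccc2nc(N3CCC(NS(=O)(=O)O)C3)ccc2c1` gives 50 nM in a functional assay on HEK293 cells for activation of melanin-concentrating hormone receptor 1 (Rattus norvegicus), read by inositol phosphate accumulation; a lower number here means that less compound is needed, a higher number that more compound is needed for the effect. Compound 2 `CC(C)C(=O)NC1CCN(c2ccc3cc(NC(=O)CCc4ccc(C(F)(F)F)cc4)ccc3n2)C1` gives 90 nM in this assay, the higher of the two numbers, although the step of a 1.8-fold higher number from compound 1 to compound 2 (0.26 log units; within the scatter) lies within the scatter. Compound 3 `CCN(CC)c1ccc2cc(NC(=O)CCc3ccc(C(F)(F)F)cc3)ccc2n1` arises from compound 2 by one change: diethylamino in place of 3-((isopropylcarbonyl)amino)pyrrolidin-1-yl on an aromatic carbon. Within the data shown here, the only measured step, a 1.8-fold higher number from compound 1 to compound 2 (0.26 log units; within the scatter), alters the same region yet keeps the five-membered non-aromatic ring, so it bears only loosely on this larger change and gives no ground to expect a direction beyond the scatter. Compound 3 is therefore expected to give 250 nM, within 60 nM to 1200 nM. That estimate corresponds to an expected step of a 2.8-fold higher number from compound 2 to compound 3 (0.44 log units; beyond the scatter).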

Compound 3, half-maximal effective concentration: 830 nM
Compound 3: middle estimate off by 3.3-fold (0.52 log units), on the low side; the measured number falls inside the stated range.
By their numbers in this assay, from the lowest: compounds 1 and 2 (each within the scatter of the next); then compound 3.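

At this position, next to the ring nitrogen, the substituent does matter: diethylamino gives a 9.2-fold higher number from compound 2 to compound 3 (0.96 log units; beyond the scatter) and a 17-fold higher number from compound 1 to compound 3 (1.22 log units; beyond the scatter) in this assay while the change on the amine nitrogen stayed within the scatter. The loss thus goes with replacing the whole substituent, not with the choice between isopropylcarbonyl and sulfo. No evidence at hand accounts for this shift. The compounds shown leave open whether the ring or its acylated or sulfonated amine carries the difference. A free amine on the same ring could separate these two.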